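The source may hold more compounds than are shown below. What is called first, only, known or untested is meant among the compounds shown, and "the series" means these compounds.

In a functional assay on HeLa cells (Homo sapiens) for antiproliferative activity, read by MTT assay, with a stated time of 72 h (a lower number here means a stronger inhibitor, a higher number a weaker inhibitor), compound 1 `O=C1COc2ccc(-c3cnc4ccccc4c3)cc2N1c1ccccc1` gives only a limit of the assay, > 40000 nM. Compound 2 `O=C1COc2ccc(-c3cnc4ccccc4c3)cc2N1` likewise gives only a limit, > 40000 nM. The step that the two limits leave unreadable from compound 1 to compound 2 is therefore not readable, because of the limit of > 40000 nM in this assay, at which 2 of the 2 values shown sit. Compound 3 `COc1cccc(N2C(=O)COc3ccc(-c4cnc5ccccc5c4)cc32)c1` differs from compound 2 by 3-methoxyphenyl in place of hydrogen on an amide-type nitrogen in a ring. No readable measured step bears on this change, so nothing in the numbers shown points in either direction. Compound 3 is expected to sit near 40000 nM, in a range from 15000 nM to 100000 nM. The step of a number no higher from compound 2 to compound 3 (the limit leaves the size open) that this estimate means is expected to stay within the usual scatter.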

Compound 3, half-maximal inhibitory concentration: 11400 nM
Compound 3: the middle estimate sits 3.5-fold (0.55 log units) above what was measured, and the stated range ends above it.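

In this assay the amide-type nitrogen now gives a readable change: there is an at least 3.5-fold lower number from compound 2 to compound 3 (0.54 log units; beyond the scatter) when 3-methoxyphenyl replaces hydrogen there. There is also an at least 3.5-fold lower number from compound 1 to compound 3 (0.54 log units; beyond the scatter) when methoxy replaces hydrogen on an aromatic carbon. Among these compounds, then, the added phenyl gives a measurable value only when it carries the methoxy group, which the earlier pair could not show.

On these data alone, the full size of both steps stays open, as each starts from a limit of the assay. Also open, as far as these compounds go, is whether an amine or a carboxylic acid in place of the methoxy would do the same.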